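A few compounds are considered here, and "the series" means these few. Any claim that something is new, unique, unknown or untested is made for them only; others in the source may bear on it.

In a functional assay on MES-SA cells (Homo sapiens) for inhibition, read by fluorescence, with a stated time of 72 h (on this read-out higher numbers stand for weaker inhibition and lower numbers for stronger inhibition), compound 3 (`Oc1ccccc1/C=N/NC(=S)Nc1cccc(C(F)(F)F)c1`) has a single value of 5070 nM and sits in the middle of the numbers shown so far. Compound 1 (`FC(F)(F)c1cccc(NC(=S)N/N=C/c2ccccn2)c1`) reads 832 nM; 850 nM (2 entries) and compound 2 (`Oc1ccccc1/C=N/NC(=S)Nc1ccccc1`) reads 11500 nM; 14000 nM (2 entries) in the same read-out. On these values, compound 3 gives weaker inhibition than compound 1 and stronger inhibition than compound 2.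

The next compound, compound 4 (`O=[N+]([O-])c1ccc(O)c(/C=N/NC(=S)Nc2cccc(C(F)(F)F)c2)c1`), keeps the frame of compound 3 and has nitro in place of hydrogen on an aromatic carbon, para to a hydroxy group (nitro in place of hydrogen on an aromatic carbon). Among the measured compounds shown here, no measured pair isolates a nitro group, and the expectation rests only on the spread of values seen in this assay so far. The expected change is small and towards stronger inhibition (a 1.4-fold lower number from compound 3 to compound 4 (0.16 log units; within the scatter)), and it may not clear the usual scatter. For compound 4 the estimated half-maximal inhibitory concentration is 3500 nM, with an expected range from 1100 nM to 11000 nM as the working bounds.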

Compound 4, half-maximal inhibitory concentration: 16400 nM
Compound 4: the middle estimate sits 4.7-fold (0.67 log units) below what was measured; measured number outside the range, above it.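

In this assay, among the compounds shown here, nitro in place of hydrogen on an aromatic carbon, para to a hydroxy group, gives the first single-place step, and it runs towards weaker inhibition: a 3.2-fold higher number from compound 3 to compound 4 (0.51 log units; beyond the scatter). This position therefore does not tolerate every substituent without a change in the read-out, and here the added nitro lowers inhibition rather than leaving it within the scatter. Compound 3 and compound 4 each rest on a single entry, but repeat entries elsewhere in the series stay close together: the several entries of compound 1 in this assay, 832 nM; 850 nM (2 entries)

As far as these compounds go, whether this loss belongs to nitro itself or to any substituent at this position stays open, and an amine, a methoxy group or a chlorine atom in the same place would separate those two readings. A single step gives no trend across substituents and no cause for the change.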